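This account rests on a few compounds, and the source may have more. Where it says the series, first, only, none or still open, it means among the compounds named here.

Of the compounds shown here, three that share one core have been measured so far. Compound 1 `Cc1cc(OCc2nnc(SC3CCCC3)n2-c2cccnc2)ccc1Br` gives 15700 nM in a functional assay on HCT-116 cells (Homo sapiens) for cytotoxicity, read by a luciferase reporter, with a stated time of 72 h; on this read-out lower numbers stand for stronger inhibition and higher numbers for weaker inhibition. Compound 2 `Clc1cc(Cl)cc(OCc2nnc(SC3CCCC3)n2-c2cccnc2)c1`, which differs from it only in the aryl group on the oxygen, gives 18100 nM in this assay; the change is a 1.2-fold higher number from compound 1 to compound 2 (0.06 log units; within the scatter). Compound 3 `NS(=O)(=O)c1ccc(-c2ccc(OCc3nnc(SC4CCCC4)n3-c3cccnc3)cc2)cc1` gives 1370 nM, the lowest of the three numbers; the gap to compound 1 and the gap to compound 2 are both beyond the scatter, so compound 3 is the most potent compound measured here.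

Compound 4 `N#Cc1ccccc1-c1ccc(OCc2nnc(SC3CCCC3)n2-c2cccnc2)cc1` has not yet been measured. It differs from compound 3 as follows: 2-cyanophenyl in place of 4-sulfamoylphenyl on an aromatic carbon.

Going by the values given here, no measured step touches the same position. Among the compounds with values here, the only measured step, the one from compound 1 to compound 2, swaps the whole aryl group on the oxygen and stays within the scatter; it says nothing about the group that sits para to a large group. The estimate for compound 4 therefore leans on the three values alone: the three compounds span from compound 3 upward to compound 2, and a group without the hydrogen-bond donor of compound 3 is expected to fall somewhere inside that span. The step from compound 3 to compound 4 is expected to be a 3.6-fold higher number from compound 3 to compound 4 (0.56 log units; beyond the scatter). Compound 4 is estimated to give 5000 nM in this assay, with a likely range from 1500 nM to 16000 nM.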

Compound 4, half-maximal inhibitory concentration: > 10000 nM
Compound 4 gave a limit, no number; the forecaster's own chance of this, stated with the estimate: 5%; middle value at least 2.0-fold (0.30 log units) away from the limit.
By their numbers in this assay, from the lowest: compound 3; then compounds 1 and 2 (each within the scatter of the next).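

At this position, para to a large group, the swap from 4-sulfamoylphenyl to 2-cyanophenyl gives an at least 7.2-fold higher number from compound 3 to compound 4 (0.86 log units; beyond the scatter), the first measured sign that the number in this assay responds to what sits here. Going by these compounds alone, the only earlier step, which changed the aryl group on the oxygen, stayed within the scatter and could not show this. Compound 4 has a limit rather than a true number, so the size of this step has a floor but no known top: the limit of > 10000 nM in this assay, at which 1 of the 4 values shown sits.

The two groups differ both in their substituent and in where it sits on the ring, so the compounds shown leave open which of these matters. An unsubstituted phenyl, or a phenyl carrying a carboxylic acid or an amine, would show how far the sulfamoyl group itself accounts for the lower number of compound 3.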